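Fluoro for methoxy on the aryl ring: a second look

This account rests on a few compounds, and the source may have more. Where it says the series, first, only, none or still open, it means among the compounds named here.

Compound 1 `CCC1=C(O)c2c(oc(-c3cccc(OC)c3)cc2=O)C(CC)(CC)C1=O` in a functional assay on KB cells (Homo sapiens) for antiproliferative activity, read by sulforhodamine B assay, with a stated time of 3 days (a lower number here means that less compound is needed, a higher number that more compound is needed for the effect), gives 13.3 uM. Compound 2 `CCC1=C(O)c2c(oc(-c3cccc(F)c3)cc2=O)C(CC)(CC)C1=O` gives only a limit of the assay, > 56.2 uM, and this is the limit of > 56.2 uM in this assay, at which 1 of the 3 values shown sits. The change between them is fluoro in place of methoxy on an aromatic carbon, and it brought an at least 4.2-fold higher number from compound 1 to compound 2 (0.62 log units; beyond the scatter). Compound 3 `CCC1=C(O)c2c(oc(-c3ccc(OC)c(OC)c3)cc2=O)C(CC)(CC)C1=O` gives 14.7 uM in this assay; it differs from compound 1 by methoxy in place of hydrogen on an aromatic carbon, and the two values show a 1.1-fold higher number from compound 1 to compound 3 (0.04 log units; within the scatter). Compound 4 `CCC1=C(O)c2c(oc(-c3ccc(OC)c(F)c3)cc2=O)C(CC)(CC)C1=O` is not yet measured; it arises from compound 3 by fluoro in place of methoxy on an aromatic carbon. Among the compounds with values here, this is the same kind of change as the one from compound 1 to compound 2, though here the place is ortho to a methoxy group as well as meta to a large group, whereas in compound 2 it is only meta to a large group. Since the earlier step was an at least 4.2-fold higher number from compound 1 to compound 2 (0.62 log units; beyond the scatter), compound 4 is expected to show a 3.7-fold higher number from compound 3 to compound 4 (0.57 log units; beyond the scatter) in this assay, with a fair chance that only a limit is reported. The estimate for compound 4 is 55 uM, between 20 uM and 150 uM.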

Compound 4, concentration for half-maximal effect: 26.7 uM
For compound 4 the middle estimate is 2.1-fold (0.31 log units) above the measured one; the measured number falls inside the stated range.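

Carried to the second core, fluoro in place of methoxy gave a 1.8-fold higher number from compound 3 to compound 4 (0.26 log units; within the scatter), so the clear step seen on the core of compound 1 did not recur as a clear step, yet the two steps cannot be told apart: the same change on two cores in this assay, an at least 4.2-fold higher number (0.62 log units; beyond the scatter) from compound 1 to compound 2 and a 1.8-fold higher number (0.26 log units; within the scatter) from compound 3 to compound 4; the limit leaves it open whether they differ.
Methoxy in place of hydrogen reads in a similar way, with an at least 2.1-fold lower number from compound 2 to compound 4 (0.32 log units; beyond the scatter) on the fluoro-bearing core, and the comparison with the core of compound 1 again stays unsettled: the same change on two cores in this assay, a 1.1-fold higher number (0.04 log units; within the scatter) from compound 1 to compound 3 and an at least 2.1-fold lower number (0.32 log units; beyond the scatter) from compound 2 to compound 4; the limit leaves it open whether they differ.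
Compound 2 stands at a limit and not at a number, so neither comparison shows how large the change truly is on that side, and one clear step does not establish a rule for the series: the limit of > 56.2 uM in this assay, at which 1 of the 4 values shown sits.

Taken together, the two changes amount to a 2.0-fold higher number from compound 1 to compound 4 (0.30 log units; within the scatter), and this is the only reading of the combined swap on the aryl ring.
The compounds shown leave open how an amine, a carboxylic acid or a longer alkoxy chain in place of the methoxy would read in this assay, and whether the three ethyl groups of the shared core can be exchanged.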